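This account rests on a few compounds, and the source may have more. Where it says the series, first, only, none or still open, it means among the compounds named here.

In a functional assay on LN-229 cells (Homo sapiens) for antiproliferative activity, with a stated time of 72 h (on this read-out higher numbers stand for weaker inhibition and lower numbers for stronger inhibition), compound 1 `CCCC#Cc1cc([C@@H]2O[C@H](CO)[C@@H](O)[C@H]2O)n2ncnc(N)c12` gives 40 nM. Compound 2 `Nc1ncnn2c([C@@H]3O[C@H](CO)[C@@H](O)[C@H]3O)cc(C#Cc3ccc(F)cc3)c12` differs from it by a 4-fluorophenyl in place of propyl on a triple-bonded carbon, and shows an at least 2500-fold higher number from compound 1 to compound 2 (3.39 log units; beyond the scatter). Compound 2 gives > 100000 nM; this is the limit of > 100000 nM in this assay, at which 1 of the 2 values shown sits, so its value in this assay is a limit, not a number. Compound 3 `Nc1ncnn2c([C@@H]3O[C@H](CO)[C@@H](O)[C@H]3O)cc(-c3ccccc3)c12` carries phenyl in place of 2-(4-fluorophenyl)ethynyl on an aromatic carbon. For the measured compounds named here, only the step from compound 1 to compound 2 bears on this change, and it was large; a smaller aryl group without the triple bond might recover part of that loss. For compound 3 the expected step is an at least 20-fold lower number from compound 2 to compound 3 (1.30 log units; beyond the scatter), so its estimated value in this assay is 5000 nM, within 300 nM to 100000 nM.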

Compound 3, half-maximal inhibitory concentration: 75100 nM
The estimate for compound 3 lay 15-fold (1.18 log units) below the measured number, within the range that was stated.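

Replacing pent-1-yn-1-yl with phenyl on this aromatic carbon gives a 1900-fold higher number from compound 1 to compound 3 (3.27 log units; beyond the scatter), so an aryl group without the triple bond does not recover the activity. Replacing 2-(4-fluorophenyl)ethynyl with phenyl gives an at least 1.3-fold lower number from compound 2 to compound 3 (0.12 log units; that floor lies within the scatter), so no gain can be claimed from this change. The value of compound 2 is a limit, not a number: the limit of > 100000 nM in this assay, at which 1 of the 3 values shown sits.

As far as these compounds go, whether the triple bond or the alkyl chain matters more remains open, and a saturated pentyl chain at this position would help separate the two. From the compounds shown here alone, whether a chain ending in an amine is tolerated here also remains open.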